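Benzyloxy ring change on an acylurea benzimidazole series

A few compounds are considered here, and "the series" means these few. Any claim that something is new, unique, unknown or untested is made for them only; others in the source may bear on it.

Measured compounds:
compound 1 `Cc1ccc(NC(=O)NC(=O)c2ccc(OCc3cccc(Cl)c3)cc2)cc1-c1nc2ccccc2[nH]1` gives 15400 nM
compound 2 `Cc1ccc(NC(=O)NC(=O)c2ccc(OCc3ccc(Cl)cc3Cl)cc2)cc1-c1nc2ccccc2[nH]1` gives 2620 nM

Within the data shown here, compound 2, in a functional assay on HT-29 cells (Homo sapiens) for inhibition, read by MTT assay, with a stated time of 48 h (a higher number here means a weaker inhibitor, a lower number a stronger inhibitor), stands lowest of the two numbers so far; its nearest neighbour is compound 1, which gives 15400 nM, and the step of a 5.9-fold lower number from compound 1 to compound 2 (0.77 log units; beyond the scatter) lies beyond the scatter. Compound 3 `Cc1ccc(NC(=O)NC(=O)c2ccc(OCc3ccc(F)cc3)cc2)cc1-c1nc2ccccc2[nH]1` is not yet measured in this assay. It differs from compound 2 in one place: 4-fluorophenyl in place of 2,4-dichlorophenyl on a saturated chain carbon bound to an oxygen on an aromatic ring. Among the measured compounds shown here, the only measured step that bears on this change is a 5.9-fold lower number from compound 1 to compound 2 (0.77 log units; beyond the scatter), where a second chlorine on the benzyl ring, and a changed pattern of substitution, went with a modest drop in the number. Compound 3 removes both chlorines and carries a single fluorine instead, so the step is expected to run the other way, back toward the value of compound 1 or somewhat past it. The estimated step is a 4.6-fold higher number from compound 2 to compound 3 (0.66 log units; beyond the scatter). Compound 3 is therefore expected to give about 12000 nM in this assay, with a likely range from 4000 nM to 40000 nM.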

Compound 3, half-maximal inhibitory concentration: 980 nM
Beside the measured number, compound 3's estimate is 12-fold (1.09 log units) above it, and the stated range ends above it.
By their numbers in this assay, from the lowest: compound 3; then compound 2; then compound 1.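

In this assay, the 4-fluorophenyl group on the saturated chain carbon bound to an oxygen on an aromatic ring gives the lowest number of the three, with a 2.7-fold lower number from compound 2 to compound 3 (0.43 log units; beyond the scatter) and a 16-fold lower number from compound 1 to compound 3 (1.20 log units; beyond the scatter). The earlier step alone could be read as more chlorine going with a lower number, but compound 3, which carries no chlorine, goes against that reading, so this position does not need a chlorine, let alone two, for the lowest number seen here. The order also does not follow the count of halogen atoms on the ring, since compound 3 with one fluorine and compound 1 with one chlorine stand at the two ends, and nothing available accounts for this order.

Each of these rings differs from the others in both its halogen and its substitution pattern, so the compounds shown leave open whether the kind of halogen or its place on the ring matters more, a question a 4-chlorophenyl group would bear on. They also leave open whether the fluorine contributes at all, which an unsubstituted phenyl group, or a ring carrying a methoxy group or an amine, would address.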